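A few compounds are considered here, and "the series" means these few. Any claim that something is new, unique, unknown or untested is made for them only; others in the source may bear on it.

In a functional assay on MCF7 cells (Homo sapiens) for cytotoxicity, read by sulforhodamine B assay, with a stated time of 24 h (a higher number here means a weaker inhibitor, a lower number a stronger inhibitor), compound 1 (`O=C1Nc2ccc(S(=O)(=O)N3CCOCC3)cc2/C1=N/c1cccc(C(F)(F)F)c1`) gives 41100 nM while compound 2 (`O=C1Nc2ccc(S(=O)(=O)N3CCOCC3)cc2/C1=N/c1ccc(C(=O)O)cc1`) gives 26700 nM and compound 3 (`O=C1Nc2ccc(S(=O)(=O)N3CCOCC3)cc2/C1=N/Nc1ccccc1`) gives 30300 nM within the scatter of both others. Compound 4 (`O=C1Nc2ccc(S(=O)(=O)N3CCOCC3)cc2/C1=N/c1ccc(Cl)cc1`) has 4-chlorophenyl in place of anilino on a double-bonded nitrogen. Within the data shown here, no measured compound carries that group, but the measured steps all change this same place. They are a 1.4-fold lower number from compound 1 to compound 3 (0.13 log units; within the scatter) and a 1.1-fold higher number from compound 2 to compound 3 (0.05 log units; within the scatter) and a 1.5-fold lower number from compound 1 to compound 2 (0.19 log units; within the scatter) with none beyond the scatter. No step beyond the scatter is therefore expected in this assay for this change. The expected step is (a 1.0-fold lower number from compound 3 to compound 4 (0.00 log units; within the scatter)). Compound 4 is estimated at 30000 nM (14000 nM to 65000 nM).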

Compound 4, half-maximal inhibitory concentration: 44300 nM
For compound 4 the middle estimate is 1.5-fold (0.17 log units) below the measured one; measured number inside the range.
By their numbers in this assay, from the lowest: compounds 2, 3, 1 and 4 (each within the scatter of the next).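

In this assay, the 4-chlorophenyl group adds a chloro-bearing ring to the groups tested on the double-bonded nitrogen, and every new step stays within the scatter (a 1.5-fold higher number from compound 3 to compound 4 (0.16 log units; within the scatter); a 1.7-fold higher number from compound 2 to compound 4 (0.22 log units; within the scatter); a 1.1-fold higher number from compound 1 to compound 4 (0.03 log units; within the scatter)). Exchanging anilino, which has a hydrogen-bond donor and acceptor, for 4-chlorophenyl, which has neither, therefore gives no step beyond the scatter. No available evidence bears on why these numbers stay so close.

Going by these compounds, whether an aliphatic amine or a longer alkyl chain at this place would give a step beyond the scatter remains open. So does the effect of any change elsewhere on the shared core.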